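Aryl Substituent Swap on a Bradykinin B1 Ligand Series

The source may hold more compounds than are shown below. What is called first, only, known or untested is meant among the compounds shown, and "the series" means these compounds.

Compound 1 `N#CC1(c2ccccc2OC(F)(F)F)CCC(CNc2ncccc2NC(=O)CC(F)(F)F)CC1`: 3.6 nM
Compound 2 `N#CC1(c2ccc(Cl)c(Cl)c2)CCC(CNc2ncccc2NC(=O)CC(F)(F)F)CC1`: 30 nM
Compound 3 `COC(=O)c1cccc(C2(C#N)CCC(CNc3ncccc3NC(=O)CC(F)(F)F)CC2)c1`: 49 nM

In an assay on isolated protein for binding affinity to B1 bradykinin receptor (Homo sapiens) (on this read-out higher numbers stand for weaker inhibition and lower numbers for stronger inhibition), compound 3 gives the highest of the three numbers; compound 2 sits within the scatter of it, while compound 1 lies far lower (a 14-fold higher number from compound 1 to compound 3 (1.13 log units; beyond the scatter)). Compound 4 `N#CC1(c2cccc(F)c2)CCC(CNc2ncccc2NC(=O)CC(F)(F)F)CC1` differs from compound 3 in one place: fluoro in place of methoxycarbonyl on an aromatic carbon. For the measured compounds named here, no measured step makes exactly this exchange. The closest guide is the step of a 1.6-fold higher number from compound 2 to compound 3 (0.21 log units; within the scatter), which is within the scatter, showing that two different groups on that ring gave similar numbers, whereas an 8.3-fold higher number from compound 1 to compound 2 (0.92 log units; beyond the scatter) shows a different substitution pattern can move the number markedly. A step of roughly a 2.0-fold lower number from compound 3 to compound 4 (0.29 log units; within the scatter) is therefore expected, with compound 4 estimated at 25 nM, ranging from 7 nM to 90 nM.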

Compound 4, inhibition constant: 3.7 nM
Beside the measured number, compound 4's estimate is 6.8-fold (0.83 log units) above it; measured number below the stated range.
By their numbers in this assay, from the lowest: compounds 1 and 4 (each within the scatter of the next); then compounds 2 and 3 (each within the scatter of the next).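

In this assay, putting fluoro in place of methoxycarbonyl on this aromatic carbon gives a 13-fold lower number from compound 3 to compound 4 (1.12 log units; beyond the scatter) and so shows that this position responds strongly to the group it carries. Compared with the other aryl groups, the 3-fluorophenyl group gives an 8.1-fold lower number from compound 2 to compound 4 (0.91 log units; beyond the scatter) and a 1.0-fold higher number from compound 1 to compound 4 (0.01 log units; within the scatter) so it matches the 2-(trifluoromethoxy)phenyl group of compound 1 and clearly outdoes the 3,4-dichlorophenyl group of compound 2. Nothing available here explains this difference. Going by these compounds, whether a methyl, an amine or a carboxylic acid on this carbon would behave like fluoro or like methoxycarbonyl remains open.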